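Replacing the Cyano Group with Azido

The compounds below may be only part of what the source reports. "The series", "measured", "known", "first", "only" and "open" are said of these compounds alone.

compound 1 `N#Cc1cc(=O)[nH]c(=O)n1[C@@H]1O[C@H](CO)[C@@H](O)[C@H]1O`: > 50000 nM
compound 2 `O=c1cc(I)n([C@@H]2O[C@H](CO)[C@@H](O)[C@H]2O)c(=O)[nH]1`: 18900 nM

In a functional assay on SKW3 cells (Homo sapiens) for antiproliferative activity, read by WST assay, with a stated time of 3 days (a higher number here means a weaker inhibitor, a lower number a stronger inhibitor), compound 1 stands at > 50000 nM, which is a limit of the assay and not a number. Compound 2 gives a true number, 18900 nM. The next compound, compound 3 `[N-]=[N+]=Nc1cc(=O)[nH]c(=O)n1[C@@H]1O[C@H](CO)[C@@H](O)[C@H]1O`, has not yet been measured. It keeps the core of compound 1 and carries azido in place of cyano on an aromatic carbon. For the measured compounds named here, the one measured step bearing on this change also removes the cyano group, putting iodo in its place: an at least 2.6-fold lower number from compound 1 to compound 2 (0.42 log units; beyond the scatter). It is a single step, so the expectation rests on thin ground. A step of similar size towards a lower number is expected in this assay, an at least 2.5-fold lower number from compound 1 to compound 3 (0.39 log units; beyond the scatter). For compound 3 the estimated value is 20000 nM, with an expected range of 6000 nM to 50000 nM.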

Compound 3, half-maximal inhibitory concentration: > 50000 nM
Compound 3: only a limit was reported; the forecaster's own chance of this, stated with the estimate: 30%; at least 2.5-fold (0.39 log units) between middle value and limit.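

In this assay compound 3 gives > 50000 nM, which is a limit of the assay and not a number. Azido in place of iodo on this aromatic carbon, next to the ring nitrogen, gives an at least 2.6-fold higher number from compound 2 to compound 3 (0.42 log units; beyond the scatter), so replacing cyano here does not by itself bring a readable value: of the three groups shown, only iodo gives one. The step between the cyano and azido compounds cannot be read, and no order of these two groups can be given: the limit of > 50000 nM in this assay, at which 2 of the 3 values shown sit.

From the compounds shown here alone, how far compound 1 and compound 3 lie beyond that limit stays open. So does whether an amine, a bromo group or a methyl group on this carbon would give a readable value, and how that value would compare with iodo.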